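The source may report more compounds than this note shows. Statements on the series, on what has been measured and on what is new or still open speak of the compounds shown alone.

Compound 1 `Cc1ccccc1OC1CCN(c2ccc(-n3ccnc3)nn2)CC1`: 39 nM in an assay on microsomes from liver for inhibition of acyl-CoA desaturase 1 (Rattus norvegicus); a lower number here means a stronger inhibitor, a higher number a weaker inhibitor
Compound 2 `FC(F)(F)c1ccccc1OC1CCN(c2ccc(-n3ccnc3)nn2)CC1`: 4 nM in this assay

Within the data shown here, compound 2 has the lowest number of the two measured compounds in this assay; its nearest neighbour is compound 1, and the only measured step is a 9.8-fold lower number from compound 1 to compound 2 (0.99 log units; beyond the scatter), a change of the group on the outer aromatic ring.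

Compound 3 `OCc1nnc(-c2ccc(N3CCC(Oc4ccccc4C(F)(F)F)CC3)nn2)o1` differs from compound 2 at the other end of the molecule: 5-(hydroxymethyl)-1,3,4-oxadiazol-2-yl in place of 1H-imidazol-1-yl on an aromatic carbon. Among the measured compounds shown here, no measured step touches this position, so the step from compound 1 to compound 2 gives no direct guidance on it; the only lesson it offers is that single-group changes can move the number beyond the scatter. Exchanging the imidazolyl for a larger, hydroxymethyl-bearing oxadiazolyl is therefore judged with low confidence, and a modest weakening, a 3.8-fold higher number from compound 2 to compound 3 (0.57 log units; beyond the scatter), is expected. Compound 3 is thus estimated at 15 nM in this assay, within a range from 3 nM to 80 nM.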

Compound 3, half-maximal inhibitory concentration: 2.9 nM
For compound 3 the middle estimate is 5.2-fold (0.71 log units) above the measured one; measured number below the stated range.
By their numbers in this assay, from the lowest: compounds 3 and 2 (each within the scatter of the next); then compound 1.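

This position accepts a considerable exchange: in this assay, putting 5-(hydroxymethyl)-1,3,4-oxadiazol-2-yl in place of 1H-imidazol-1-yl gives a 1.4-fold lower number from compound 2 to compound 3 (0.14 log units; within the scatter) and leaves the two compounds indistinguishable. The entering group has more heavy atoms and more hydrogen-bond acceptors, and it brings a hydrogen-bond donor where the imidazolyl has none, yet the number stays within the usual scatter. No available measurement bears on the reason for this result.

The compounds shown do not separate the contribution of the oxadiazolyl ring from that of its hydroxymethyl group, which a methyl, an amine or a carboxylic acid in that place could help to resolve. As far as these compounds go, it also remains open whether this exchange would give a similar result with methyl instead of trifluoromethyl on the outer aromatic ring.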